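Swapping Naphthalenyl for Fluoroindazolyl: An Expected Shift

A few compounds are considered here, and "the series" means these few. Any claim that something is new, unique, unknown or untested is made for them only; others in the source may bear on it.

Going by the values given here, in an assay on cells for binding affinity to 5-hydroxytryptamine receptor 1D (Homo sapiens), read by radioligand binding (a higher number here means a weaker inhibitor, a lower number a stronger inhibitor), compound 2 `NC(=O)c1ccc2c(c1)CCOC2CCN1CC=C(c2cccc3ccccc23)CC1` gives 5.4 nM, the lowest of the two numbers measured so far. Compound 1 `NC(=O)c1ccc2c(c1)CCOC2CCN1CC=C(c2csc3cc(F)ccc23)CC1` gives 20 nM in this assay. Among the compounds with values here, the single measured step, a 3.7-fold lower number from compound 1 to compound 2 (0.57 log units; beyond the scatter), shows that the bicyclic group on the double-bonded ring carbon changes the number modestly. Compound 3 `NC(=O)c1ccc2c(c1)CCOC2CCN1CC=C(c2[nH]nc3cc(F)ccc23)CC1` alters that same place: 6-fluoro-2H-indazol-3-yl in place of naphthalen-1-yl on a double-bonded ring carbon. Within the data shown here, no measured step covers this new group, so the expectation rests loosely on the one step known. Compound 3 is expected to give about 25 nM, within 6 nM to 110 nM. For compound 3 this estimate means a 4.6-fold higher number from compound 2 to compound 3 (0.67 log units; beyond the scatter).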

Compound 3, inhibition constant: 24 nM
Estimate against measurement, compound 3: 1.0-fold (0.02 log units) above; low and high end bracket the measured number.
By their numbers in this assay, from the lowest: compound 2; then compounds 1 and 3 (each within the scatter of the next).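

Naphthalen-1-yl now stands apart from a second group at this position, with 6-fluoro-2H-indazol-3-yl giving a 4.4-fold higher number from compound 2 to compound 3 (0.65 log units; beyond the scatter) in a step of modest size. The two fluorinated groups cannot be told apart, with 6-fluoro-2H-indazol-3-yl in place of 6-fluoro-1-benzothiophen-3-yl giving a 1.2-fold higher number from compound 1 to compound 3 (0.08 log units; within the scatter) in this comparison. Nothing at hand explains these numbers.

Whether the fluorine or the ring atoms account for the gap to compound 2 stays open: both fluorinated groups differ from naphthalen-1-yl in both respects. A 6-fluoronaphthalen-1-yl or an unfluorinated indazol-3-yl group would separate the two.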